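Shifting the Chlorine on the Benzyl Arm of Compound 3

The source may report more compounds than this note shows. Statements on the series, on what has been measured and on what is new or still open speak of the compounds shown alone.

Compound 1, `COc1ccc(/C=C2\CN(C(=S)SCc3cn(Cc4ccccc4Cl)nn3)C/C(=C\c3ccc(OC)cc3)C2=O)cc1`, in a functional assay on DU-145 cells (Homo sapiens) for cytotoxicity, read by MTT assay, with a stated time of 24 h (a higher number here means a weaker inhibitor, a lower number a stronger inhibitor), gives only a limit of the assay, > 80000 nM.
Compound 2, `O=C1/C(=C/c2ccccc2F)CN(C(=S)SCc2cn(Cc3cccc(Cl)c3)nn2)C/C1=C\c1ccccc1F`, likewise gives only a limit in this assay, > 80000 nM.
Compound 3, `O=C1/C(=C/c2ccccc2F)CN(Cc2cn(Cc3ccccc3Cl)nn2)C/C1=C\c1ccccc1F`, gives a number in this assay, 7500 nM.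

For the measured compounds named here, of the three measured compounds, compound 3 is the only one with a measured number; the other two sit at the limit of > 80000 nM in this assay, at which 2 of the 3 values shown sit, which is a limit of the assay and not a number. Going by the values given here, compound 3 therefore stands alone, and no pair of measured compounds differs in a single place, so no measured step is available for comparison.

The unmeasured compound 4, `O=C1/C(=C/c2ccccc2F)CN(Cc2cn(Cc3cccc(Cl)c3)nn2)C/C1=C\c1ccccc1F`, differs from compound 3 in one place: 3-chlorophenyl in place of 2-chlorophenyl on a saturated chain carbon bound to an aromatic nitrogen. Compounds 1 and 2 carry the same two chlorophenyl groups, but both are limits, so they say nothing about the size of this change.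

The change is expected to move the half-maximal inhibitory concentration little, a step from compound 3 to compound 4 of a 1.2-fold higher number from compound 3 to compound 4 (0.08 log units; within the scatter), not beyond the scatter. Compound 4 is estimated at 9000 nM, between 3000 nM and 30000 nM.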

Compound 4, half-maximal inhibitory concentration: 4300 nM
For compound 4 the middle estimate is 2.1-fold (0.32 log units) above the measured one, and the stated range covers the measured number.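

In this assay, for the compounds shown here, the pair gives the first step that can be read at this position, a 1.7-fold lower number from compound 3 to compound 4 (0.24 log units; within the scatter). On this evidence, 2-chlorophenyl and 3-chlorophenyl on a saturated chain carbon bound to an aromatic nitrogen are not told apart, and the chlorine can take either of these two places without a change beyond the scatter. Compounds 1 and 2 carry the same two chlorophenyl groups but could not show this, as neither gives a number, only a limit of the assay: the limit of > 80000 nM in this assay, at which 2 of the 4 values shown sit.

The compounds shown give no reason for this result and do not say whether the same holds with other groups on the shared core. They also leave open what an amine or a carboxylic acid in place of the chlorine would do at this position.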